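Swapping a chloropyrazole for a fused bicyclic ring

The compounds below may be only part of what the source reports. "The series", "measured", "known", "first", "only" and "open" are said of these compounds alone.

Compound 1 `CCCC(Oc1ccc(-n2cc(Cl)cn2)cc1)c1ccc(C(=O)NCCC(=O)O)cc1` was tested in a functional assay on cells for antagonist activity at Glucagon receptor (Homo sapiens), read by cAMP accumulation, in the presence of a further agent that is not named here (a higher number here means a weaker inhibitor, a lower number a stronger inhibitor), where compound 1 gives 6500 nM. Of the two numbers obtained in this assay, this is the higher one, so compound 1 is the weaker inhibitor of the pair. The nearest measured value belongs to compound 3 `CCCC(Nc1ccc(-n2cc(C(F)(F)F)cn2)nc1)c1ccc(C(=O)NCCC(=O)O)cc1`, which gives 1300 nM in this assay, a gap that lies beyond the usual scatter. Compound 2 `CCC(Oc1ccc(-n2cc(C(F)(F)F)cn2)cc1)c1ccc(C(=O)NCCC(=O)O)cc1` reached only > 22000 nM in this assay, which is a limit of the assay and not a number (the limit of > 22000 nM in this assay, at which 1 of the 3 values shown sits).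

Compound 4 `CCCC(Oc1ccc(-n2cc3c(n2)CCCC3)cc1)c1ccc(C(=O)NCCC(=O)O)cc1` has not yet been measured. It differs from compound 1 in one place: a group of 9 heavy atoms (7 carbon, 2 nitrogen; one five-membered aromatic ring with 2 hetero atoms, one six-membered non-aromatic ring of carbon only) in place of a group of 6 heavy atoms (3 carbon, 2 nitrogen, 1 chlorine; one five-membered aromatic ring with 2 hetero atoms), on an aromatic carbon. For the measured compounds named here, no pair of measured compounds in this set shares that change, so no direct comparison exists. The expected step in this assay is a 1.6-fold lower number from compound 1 to compound 4 (0.21 log units; within the scatter), small in size and leaning toward a somewhat stronger inhibitor, though it may well fall within the scatter. Compound 4 is estimated at 4000 nM in this assay, with a range from 1000 nM to 16000 nM.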

Compound 4, antagonist equilibrium constant in the Glucagon receptor assay: 4200 nM
Estimate against measurement, compound 4: 1.1-fold (0.02 log units) below; the measured number falls inside the stated range.
By their numbers in the Glucagon receptor assay, from the lowest: compound 3; then compounds 4 and 1 (each within the scatter of the next). At a limit, above all of these: compound 2.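

Trading the 4-chloro-1H-pyrazol-1-yl group for the larger fused group gives, in the Glucagon receptor assay, a 1.5-fold lower number from compound 1 to compound 4 (0.19 log units; within the scatter), so at this place on the aromatic carbon the chlorine can go and a second, non-aromatic ring can enter with no clear change in inhibition. The added atoms leave lipophilicity equally unmoved: in a physicochemical assay for lipophilicity, using the shake flask method, at pH 7.4 (a lower number here means a more polar compound, a higher number a more lipophilic compound), compound 1 gives 2.6 and compound 4 gives 2.7, two values within the usual scatter of each other. Nothing shown here explains why so large a change in the group leaves both numbers so close.

Still open, as far as these compounds go, is whether any group at this place can move the inhibition beyond the scatter, for example a nitrile or a methyl in place of the chlorine. It is equally unclear whether a ring carrying an amine, such as piperidine, would be accepted as readily as the carbon-only ring of compound 4.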